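Bromine on the Indole Ring: Expected Effect on Inhibition

A few compounds are considered here, and "the series" means these few. Any claim that something is new, unique, unknown or untested is made for them only; others in the source may bear on it.

Measured compounds:
compound 1 `COc1ccc(/C(Cl)=C/C=C(\C#N)C(=O)c2c[nH]c3ccccc23)cc1` gives 23.4% in a functional assay for inhibition, with a stated time of 30 min, tested at 1 mM; a lower number here means less inhibition, a higher number more inhibition at the concentration tested (going by the name of the read-out)
compound 2 `COc1cc(/C(Cl)=C/C=C(\C#N)C(=O)c2c[nH]c3ccccc23)cc(OC)c1OC` gives 21.1%
compound 3 `Cc1[nH]c2ccccc2c1C(=O)/C(C#N)=C/C=C(\Cl)c1ccc(Br)cc1` gives 15.8%

All three compounds share one core and show only modest inhibition at the tested concentration. The number for compound 2 differs from that of compound 1 and from that of compound 3 by less than the usual scatter of repeated measurements, so the three values cannot be told apart with confidence, and none of the three can be called stronger or weaker than the others.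

Compound 4 `COc1cc(/C(Cl)=C/C=C(\C#N)C(=O)c2c[nH]c3ccc(Br)cc23)cc(OC)c1OC` is the next compound to be tested. It differs from compound 2 in one place: bromo in place of hydrogen on an aromatic carbon. Cut one bond further out, the change reads 1H-indol-3-yl to 5-bromo-1H-indol-3-yl. For the measured compounds named here, no pair of measured compounds shows this exact change, so no measured step can guide the expectation directly.

Going by the values given here, with no measured step of this kind, the expected step from compound 2 to compound 4 is small, a number 2.9 percentage points higher from compound 2 to compound 4 (within the scatter), and not beyond the scatter in either direction. For compound 4 the estimate in this assay is 24%, with a range from 10% to 40%.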

Compound 4, a percentage reported as inhibition, at one concentration (the size of the read-out at that concentration, not a potency): 26.3%
Estimate against measurement, compound 4: 2.3 percentage points below; the range from low to high includes it.
By their numbers in this assay, from the lowest: compounds 3, 2, 1 and 4 (each within the scatter of the next, the first and the last beyond it).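

For the compounds shown here, this is the first step that changes one place only: in this assay, bromo in place of hydrogen, which turns 1H-indol-3-yl into 5-bromo-1H-indol-3-yl, gives a number 5.2 percentage points higher from compound 2 to compound 4 (within the scatter). This carbon of the six-membered aromatic ring can therefore carry a bromine atom with no change in inhibition that can be told from the scatter, so the step shows neither a gain nor a loss at the one concentration tested. No measurement at hand explains the size of this step.

Going by these compounds, whether an amine, a carboxylic acid or a methoxy group at the same carbon would move the number beyond the scatter remains open. Also open, on these data alone, is whether the same bromo change on compound 1 would give a similar step.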